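A few compounds are considered here, and "the series" means these few. Any claim that something is new, unique, unknown or untested is made for them only; others in the source may bear on it.

Working notes on the urea series. Two compounds have a number in an assay on CHO-K1 cells for antagonist activity at transient receptor potential cation channel subfamily V member 1 (Homo sapiens), read by FLIPR and calcium flux, with a stated time of 6 min; on this read-out lower numbers stand for stronger inhibition and higher numbers for weaker inhibition. Compound 1 `Cn1ncc2c(NC(=O)NCc3cc(C(F)(F)F)nn3-c3cccc(C(F)(F)F)c3)cccc21` gives 1.4 nM in this assay. For the measured compounds named here, compound 2 `Cn1ncc2c(NC(=O)NCc3cc(C(F)(F)F)nn3-c3ccc(F)cc3)cccc21` gives 8.4 nM in this assay, the higher of the two numbers, and the only measured step, 4-fluorophenyl in place of 3-(trifluoromethyl)phenyl on an aromatic nitrogen, reads a 6.0-fold higher number from compound 1 to compound 2 (0.78 log units; beyond the scatter).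

Compound 3 `Cn1ncc2c(NC(=O)NCc3cc(C(F)(F)F)nn3-c3ccc(C(C)(C)C)cc3)cccc21` is not yet measured in this assay. It differs from compound 2 in one place: tert-butyl in place of fluoro on an aromatic carbon. Going by the values given here, the single measured step bears on it only loosely, since that step exchanges the whole aryl group and touches a different position of the ring, whereas here the aryl is kept and only the group para to the large group is exchanged, fluoro leaving and tert-butyl entering. What the step does show is that the aryl on the aromatic nitrogen is a place where the number moves beyond the scatter, so a shift in this assay for compound 3 is plausible, its direction not fixed by the data; a modest move to a lower number is the working expectation, estimated as a 2.4-fold lower number from compound 2 to compound 3 (0.38 log units; beyond the scatter). Compound 3 is therefore expected to give about 3.5 nM in this assay, within a range from 0.8 nM to 15 nM.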

Compound 3, inhibition constant: 13.2 nM
Compound 3: middle estimate off by 3.8-fold (0.58 log units), on the low side, and the stated range covers the measured number.
By their numbers in this assay, from the lowest: compound 1; then compounds 2 and 3 (each within the scatter of the next).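

At this position, on an aromatic carbon para to a large group, the exchange of fluoro for tert-butyl in this assay gives no separation (a 1.6-fold higher number from compound 2 to compound 3 (0.20 log units; within the scatter)), even though the entering group counts 4 heavy atoms against 1 for the group leaving, a point the earlier whole-aryl step could not address. The second aryl exchange away from compound 1 also lies beyond the scatter (a 9.4-fold higher number from compound 1 to compound 3 (0.97 log units; beyond the scatter)), so compound 1 now stands apart from both compounds carrying a group at this position, though it differs from them in both the group and its place on the ring. No measurement is available here that explains either result.

The compounds shown do not separate the effect of the group from that of its place on the ring; trifluoromethyl on the carbon that carries fluoro in compound 2 would address that directly. They also leave open whether the flat reading from fluoro to tert-butyl extends to an amine, a carboxylic acid or a longer alkyl chain at the same carbon, since both groups compared here carry no hydrogen-bond donors, no hydrogen-bond acceptors and no net charge.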